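The source may report more compounds than this note shows. Statements on the series, on what has been measured and on what is new or still open speak of the compounds shown alone.

Compound 1 `COc1ccc(C(F)(F)F)cc1Nc1ncc(C(F)(F)F)c(N2Cc3cccc(N(C)S(C)(=O)=O)c3C2)n1`: in a functional assay on U-87MG ATCC cells for antiproliferative activity against U-87 MG (Homo sapiens), read by spectrophotometry, with a stated time of 2 days (a lower number here means a stronger inhibitor of growth, a higher number a weaker inhibitor of growth), compound 1 gives > 30000 nM, a limit of the assay rather than a number.
Compound 2 `Cc1ccc(Nc2ncc(C(F)(F)F)c(N3Cc4cccc(N(C)S(C)(=O)=O)c4C3)n2)c(Cl)c1`: compound 2 gives > 30000 nM, again only a limit.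
Compound 3 `COc1cc(Nc2ncc(C(F)(F)F)c(N3Cc4cccc(N(C)S(C)(=O)=O)c4C3)n2)cc(C(F)(F)F)c1`: compound 3 gives > 30000 nM, also a limit.

Compound 3 therefore stands where the other two stand, with no number to set it apart; all three sit at the limit of > 30000 nM in this assay, at which 3 of the 3 values shown sit. Compound 4 `Cc1ccc(Nc2ncc(C(F)(F)F)c(N3Cc4cccc(N(C)S(C)(=O)=O)c4C3)n2)c(C)c1` is not yet measured. It differs from compound 3 in one place: 2,4-dimethylphenyl in place of 3-methoxy-5-(trifluoromethyl)phenyl on a nitrogen on an aromatic ring. The measured steps that change this same group, a step that the two limits leave unreadable from compound 1 to compound 2, a step that the two limits leave unreadable from compound 1 to compound 3 and a step that the two limits leave unreadable from compound 2 to compound 3, cannot be sized: both ends of each are limits. From them no direction is expected for a step that the limit leaves unreadable from compound 3 to compound 4 beyond compound 4 remaining at the limit. Compound 4 is estimated at 45000 nM, within 15000 nM to 150000 nM.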

Compound 4, concentration for 50% growth inhibition: > 30000 nM
Compound 4 gave a limit, no number; the forecaster's own chance of this, stated with the estimate: 85%; the middle value lies beyond the limit too.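

No step from compound 1, compound 2 or compound 3 to compound 4 can be read, since all four results are limits, not numbers: the limit of > 30000 nM in this assay, at which 4 of the 4 values shown sit.

The compounds shown leave open how strongly any of them inhibits growth in this assay, and whether changing the group on the nitrogen makes any difference.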